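This account rests on a few compounds, and the source may have more. Where it says the series, first, only, none or still open, it means among the compounds named here.

Measured compounds:
compound 1, `OC[C@H]1O[C@@H](n2cnc3c(NCc4ccccc4)nccc32)C[C@@H]1O`: 15%
compound 2, `[O-][n+]1ccc2c(c1)ncn2[C@H]1C[C@H](O)[C@@H](CO)O1`: 0%
compound 3, `OC[C@H]1OC(n2cnc3c(Nc4ccccc4)nccc32)[C@H](O)[C@@H]1O`: 4%

In a functional assay (Homo sapiens) for inhibition of Nucleic Acid, tested at 100 uM (on this read-out higher numbers stand for more inhibition at the one concentration tested (going by the name of the read-out) and lower numbers for less inhibition), compound 1 stands highest of the three numbers. Compound 3 lies below it by a gap beyond the scatter, and compound 2 lies further below, also beyond the scatter. Going by the values given here, no two measured compounds differ in only one place, so no single step has been measured yet.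

Compound 4, `OC[C@H]1O[C@@H](n2cnc3c(Cl)nccc32)C[C@@H]1O`, differs from compound 1 by chloro in place of benzylamino on an aromatic carbon. In this assay the step is expected to be a number 10 percentage points lower from compound 1 to compound 4 (within the scatter), because compound 2 gives 0% and compound 3 gives 4% while only compound 1 carries the benzylamino group. Compound 4 is expected at 5%, within 0% to 15%.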

Compound 4, a percentage reported as inhibition, at one concentration (the size of the read-out at that concentration, not a potency): 5%
Compound 4: the middle estimate sits on the measured number at the digits printed; the range from low to high includes it.
By their numbers in this assay, from the lowest: compounds 2, 3, 4 and 1 (each within the scatter of the next, the first and the last beyond it).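

In this assay, going by these compounds alone, chloro in place of benzylamino on an aromatic carbon next to the ring nitrogen gives a number 10 percentage points lower from compound 1 to compound 4 (within the scatter), the first single-place step. At this position, the exchange removes the six-membered aromatic ring of carbon only and the hydrogen-bond donor without separating the two compounds beyond the scatter, so this pair does not tie the number of compound 1 to benzylamino. Nothing at hand explains the step. Open, going by these compounds, is whether a morpholine or a methoxy group on this carbon would stand apart from chloro and benzylamino. Also open, on these data alone, is whether a longer chain between the ring and the amine nitrogen would give a step beyond the scatter.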